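The source may hold more compounds than are shown below. What is called first, only, known or untested is meant among the compounds shown, and "the series" means these compounds.

Compound 1 `CCOC(=O)c1cnc(-c2csc(C)n2)nc1NN1C(=O)C=C(C)C1=O` is the weakest-looking member of the small set shown here. In a functional assay on Jurkat cells for inhibition of nuclear factor NF-kappa-B complex (Homo sapiens) (on this read-out higher numbers stand for weaker inhibition and lower numbers for stronger inhibition), compound 1 gives 8000 nM, the highest of the three numbers, while compound 2 `CCOC(=O)c1cnc(-c2ccc(OC)cc2)nc1NN1C(=O)C=C(C)C1=O` gives 900 nM and compound 3 `CCOC(=O)c1cnc(-c2cc3ccccc3s2)nc1NN1C(=O)C=C(C)C1=O` gives 4000 nM. The two measured steps that start from compound 1 both exchange the same aromatic group for another aromatic group: an 8.9-fold lower number from compound 1 to compound 2 (0.95 log units; beyond the scatter), and a 2.0-fold lower number from compound 1 to compound 3 (0.30 log units; within the scatter), the latter within the scatter. Compound 4 `CCOC(=O)c1cnc(C2CC2)nc1NN1C(=O)C=C(C)C1=O` is the next compound to be measured in this assay. The change from compound 1 to compound 4 is cyclopropyl in place of 2-methyl-1,3-thiazol-4-yl on an aromatic carbon. This step differs in kind from the two measured ones, since cyclopropyl is a three-membered non-aromatic ring of carbon only, with no hydrogen-bond acceptors, whereas both measured replacements kept an aromatic ring at the same place. For the measured compounds named here, no measured step therefore speaks directly to this change, and the account can only note that every replacement of the 2-methyl-1,3-thiazol-4-yl group tried so far lowered the number, once beyond the scatter. Compound 4 is expected to stay close to compound 1, at an estimated 8000 nM, within a wide range from 2000 nM to 32000 nM, that is an expected step of no change at the digits printed from compound 1 to compound 4 (within the scatter).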

Compound 4, half-maximal inhibitory concentration: 1000 nM
The estimate for compound 4 lay 8.0-fold (0.90 log units) above the measured number, outside the stated range (below it).
By their numbers in this assay, from the lowest: compounds 2 and 4 (each within the scatter of the next); then compounds 3 and 1 (each within the scatter of the next).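

In this assay the exchange gives an 8.0-fold lower number from compound 1 to compound 4 (0.90 log units; beyond the scatter), which shows that an aromatic ring is not needed at this place, on an aromatic carbon between two ring nitrogen atoms, for the number to fall: cyclopropyl, a three-membered non-aromatic ring of carbon only with no hydrogen-bond acceptors, also lowers it. The same group gives a 4.0-fold lower number from compound 3 to compound 4 (0.60 log units; beyond the scatter), while a 1.1-fold higher number from compound 2 to compound 4 (0.05 log units; within the scatter) stays within the scatter, so in this assay compound 4 cannot be told apart from compound 2, even though their groups at this place have little in common beyond being rings. No measurement at hand offers a reason for these steps.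

The compounds shown leave open whether a ring is needed at all at this place, since a methyl group, an open chain such as isopropyl or an amine such as dimethylamino would each test that. They also leave open whether sulfur matters, as compound 1 and compound 3 both carry it and both give the higher numbers, yet their rings differ from those of compound 2 and compound 4 in other ways too.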